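Series notes: phenyl extension on the aryl arm of compound 2

This account rests on a few compounds, and the source may have more. Where it says the series, first, only, none or still open, it means among the compounds named here.

In a functional assay on the whole organism (strain Wistar) for inhibition, with Rattus norvegicus as the target, read by paw edema, with stated times of 30 min and 3 h, at a dose of 200 mg/kg by the oral route (on this read-out lower numbers stand for less inhibition and higher numbers for more inhibition at the one dose given (going by the name of the read-out)), compound 1 `O=C(O)c1cccc(-n2c(-c3ccccc3)cc3c2CCCC3)c1` gives 20%. Compound 2 `O=C(O)c1cc(-n2c(-c3ccccc3)cc3c2CCCC3)ccc1O` shows a number at least 40 percentage points higher from compound 1 to compound 2 (beyond the scatter). Compound 2 stands at a limit rather than a number, >= 60%, that is the limit of >= 60% in this assay, at which 1 of the 3 values shown sits. Compound 3 `CC(=O)Nc1cc(-n2c(-c3ccccc3)cc3c2CCCC3)cc(C(=O)O)c1O` gives 0%, showing a number at least 60 percentage points lower from compound 2 to compound 3 (beyond the scatter). Compound 4 `O=C(O)c1cc(-n2c(-c3ccc(-c4ccccc4)cc3)cc3c2CCCC3)ccc1O` is not yet measured; it differs from compound 2 by phenyl in place of hydrogen on an aromatic carbon. Both measured steps concern a different part of the molecule from this change, so neither bears on it directly, and no step beyond the scatter is expected in this assay. Compound 4 is estimated at 60%, between 35% and 80%. The step this implies, a number no higher from compound 2 to compound 4 (the limit leaves the size open), is expected to lie within the scatter.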

Compound 4, a percentage reported as inhibition, in the whole organism at one dose (the size of the read-out at that dose, not a potency): 50%
Compound 4: middle estimate off by 10 percentage points, on the high side; the measured number falls inside the stated range.
By their numbers in this assay, from the lowest: compound 3; then compound 1; then compound 4. At a limit, above all of these: compound 2.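

Phenyl in place of hydrogen, on an aromatic carbon para to a large group, is the only change shown on this aryl arm, and in this assay it gives a number at least 10 percentage points lower from compound 2 to compound 4 (that floor lies within the scatter). This place therefore accepts an added six-membered aromatic ring, with compound 4 still reading 50%. The size of the step stays open since the value of compound 2 is a limit: the limit of >= 60% in this assay, at which 1 of the 4 values shown sits.

The compounds shown leave open how a methoxy or an amine at this place would read. Also open, from the compounds shown here alone, is whether the hydroxy of compound 4 still matters with phenyl present.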